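Adding an Amino Group to Compound 1: Expected Cytotoxicity

The source may hold more compounds than are shown below. What is called first, only, known or untested is meant among the compounds shown, and "the series" means these compounds.

Measured so far:
compound 1, `ClCc1cccc(Cn2cnc3c(Cl)ncnc32)c1`: 10000 nM
compound 2, `ClCc1ccc(Cn2cnc3c(Cl)nc(Cl)nc32)cc1`: 7590 nM

These numbers come from a functional assay on HCT-15 cells (Homo sapiens) for cytotoxicity, read by sulforhodamine B assay, with a stated time of 48 h; a higher number here means that more compound is tolerated, a lower number that less compound is tolerated. Compound 1 gives the highest of the two numbers, but compound 2 lies within the scatter of it, so the two cannot be ranked. Compound 3, `Nc1nc(Cl)c2ncn(Cc3cccc(CCl)c3)c2n1`, is not yet measured. It differs from compound 1 by amino in place of hydrogen on an aromatic carbon. Going by the values given here, no measured pair shows this change, so nothing supports expecting a shift beyond the scatter in either direction. Compound 3 is therefore estimated at 10000 nM, with a range from 3000 nM to 30000 nM. The expected step is no change at the digits printed from compound 1 to compound 3 (within the scatter).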

Compound 3, concentration lethal to 50% of the cells: 33100 nM
The estimate for compound 3 lay 3.3-fold (0.52 log units) below the measured number, and the stated range ends below it.
By their numbers in this assay, from the lowest: compounds 2 and 1 (each within the scatter of the next); then compound 3.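

Amino in place of hydrogen on an aromatic carbon, between two ring nitrogen atoms, gives a 3.3-fold higher number from compound 1 to compound 3 (0.52 log units; beyond the scatter) in this assay and so shows that this position can alter how much compound the cells tolerate. Going by these compounds alone, this is the first single change here whose step lies beyond the scatter, and it goes towards more compound being tolerated. Nothing measured here explains the shift.

On these data alone, it remains open whether a methylamino or a hydroxy group on this carbon would move the number in the same direction. One step also cannot show whether amino would act the same way in compounds with a different chloromethyl arrangement.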